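The source may report more compounds than this note shows. Statements on the series, on what has been measured and on what is new or still open speak of the compounds shown alone.

Measured so far in a functional assay on MCF7 cells (Homo sapiens) for antiproliferative activity; on this read-out lower numbers stand for stronger inhibition and higher numbers for weaker inhibition:
- compound 1 `O=C(Nc1ccc(O)c2c(=O)cc(-c3ccccc3Cl)oc12)c1ccccc1` gives 7100 nM
- compound 2 `COc1ccc(C(=O)Nc2ccc(O)c3c(=O)cc(-c4ccccc4Cl)oc23)cc1` gives 3500 nM

Among the compounds with values here, of these two, compound 1 has the higher number and so shows the weaker inhibition, with compound 2 as its only neighbour on the scale. The next compound to consider is compound 3 `O=C(Nc1c(O)cc(O)c2c(=O)cc(-c3ccccc3Cl)oc12)c1ccccc1`, which has not yet been measured. It differs from compound 1 by a hydroxy in place of hydrogen on an aromatic carbon, ortho to a benzamido group and meta to a hydroxy group (hydroxy in place of hydrogen on an aromatic carbon).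

Within the data shown here, the only measured step that offers guidance is a 2.0-fold lower number from compound 1 to compound 2 (0.31 log units; beyond the scatter), a modest change that comes from methoxy in place of hydrogen on an aromatic carbon. That change lies elsewhere in the molecule, so it gives a rough idea of size but does not settle direction. Among the measured compounds shown here, no measured compound carries the new hydroxy. A small step is expected in this assay, estimated as a 1.4-fold lower number from compound 1 to compound 3 (0.15 log units; within the scatter), with the direction uncertain. Compound 3 is expected near 5000 nM, with an estimated range of 1700 nM to 15000 nM as the likely span.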

Compound 3, half-maximal inhibitory concentration: 8500 nM
The estimate for compound 3 lay 1.7-fold (0.23 log units) below the measured number; the measured number falls inside the stated range.
By their numbers in this assay, from the lowest: compound 2; then compounds 1 and 3 (each within the scatter of the next).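

In this assay, a hydroxy on this aromatic carbon, ortho to a benzamido group and meta to a hydroxy group, gives a 1.2-fold higher number from compound 1 to compound 3 (0.08 log units; within the scatter), so compound 1 and compound 3 cannot be told apart on this read-out. The earlier step, a 2.0-fold lower number from compound 1 to compound 2 (0.31 log units; beyond the scatter), came from a methoxy elsewhere in the molecule and said nothing about this carbon, whereas it is now clear that this carbon can carry a hydroxy with no change beyond the usual scatter. No supporting measurement bears on this result.

On this carbon, the compounds shown carry only hydrogen or hydroxy, so a single substitution cannot show whether the position is insensitive to change in general or whether an amine, a carboxylic acid or a longer chain such as ethoxy would move the number clearly in either direction. As far as these compounds go, it also remains open whether the new hydroxy and the methoxy of compound 2 would work independently if both were placed on the same molecule.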